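The compounds below may be only part of what the source reports. "The series", "measured", "known", "first", "only" and "open" are said of these compounds alone.

Series values in a functional assay on HOS cells (Homo sapiens) for antiproliferative activity, with a stated time of 72 h; on this read-out higher numbers stand for weaker inhibition and lower numbers for stronger inhibition:

- compound 1 `OC[C@H]1O[C@@H](n2cnc3c(NCc4ccc(F)cc4)ncnc32)[C@H](O)[C@@H]1O`: 13200 nM
- compound 2 `OC[C@H]1O[C@@H](n2cnc3c(NCc4ccccc4Cl)ncnc32)[C@H](O)[C@@H]1O`: > 166000 nM (a limit)
- compound 3 `OC[C@H]1O[C@@H](n2cnc3c(NCc4cccc(Br)c4)ncnc32)[C@H](O)[C@@H]1O`: > 166000 nM (a limit)

Compound 3 sits at the limit of > 166000 nM in this assay, at which 2 of the 3 values shown sit. Its entry gives no number, so any step away from it can be read in one direction only.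

The next compound is compound 4 `COc1ccccc1CNc1ncnc2c1ncn2[C@@H]1O[C@H](CO)[C@@H](O)[C@H]1O`, not yet measured. It carries 2-methoxyphenyl in place of 3-bromophenyl on a saturated chain carbon bound to a nitrogen on an aromatic ring.

Within the data shown here, two measured steps bear on this change, both large and beyond the scatter: an at least 12-fold higher number from compound 1 to compound 2 (1.09 log units; beyond the scatter), and an at least 12-fold higher number from compound 1 to compound 3 (1.09 log units; beyond the scatter). The remaining step, a step that the two limits leave unreadable from compound 2 to compound 3, adds no size. Of the three measured compounds, only compound 1 gives a number, so the evidence for a readable value rests on a single compound.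

Going by an at least 12-fold higher number from compound 1 to compound 2 (1.09 log units; beyond the scatter) and an at least 12-fold higher number from compound 1 to compound 3 (1.09 log units; beyond the scatter), compound 4 is expected to remain weak in this assay, and more likely than not to be reported only as a limit. Any readable number would lie on the lower side of that limit. The estimated step is an at least 1.6-fold lower number from compound 3 to compound 4 (0.22 log units; that floor lies within the scatter). For compound 4 the estimate is 100000 nM, with an expected range of 20000 nM to 250000 nM.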

Compound 4, half-maximal inhibitory concentration: > 166000 nM
Compound 4 was reported as a limit; the forecaster's own chance of this, stated with the estimate: 60%; middle value at least 1.6-fold (0.22 log units) from the limit.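

In this assay compound 4 gives > 166000 nM, which is a limit and not a number, so a third substituted benzyl group now fails to give a readable value. Replacing 4-fluorophenyl with 2-methoxyphenyl gives an at least 12-fold higher number from compound 1 to compound 4 (1.09 log units; beyond the scatter), which extends the loss seen with the halogen-bearing groups to a group containing oxygen. No step among compounds 2, 3 and 4 can be read, and compound 1 is the one exception to the pattern, as 2-methoxyphenyl, with 1 hydrogen-bond acceptor against 0 for 3-bromophenyl, still leaves compound 4 at the limit shared by the series:  the limit of > 166000 nM in this assay, at which 3 of the 4 values shown sit.

Still open, as far as these compounds go, is whether the readable value of compound 1, 13200 nM, depends on the fluorine itself or on where the group sits on the ring, a question that 4-methoxyphenyl, 4-chlorophenyl or unsubstituted phenyl at the same place could answer. From the compounds shown here alone, the order of compounds 2, 3 and 4 also remains unknown, and testing them at concentrations beyond the limit would be needed to resolve it.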